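Series notes: shortening the alkyl substituent on the shared core

The source may hold more compounds than are shown below. What is called first, only, known or untested is meant among the compounds shown, and "the series" means these compounds.

Three compounds share one core: compound 1 `CCc1nc(C)c2cnnc(S)n12`, compound 2 `Cc1nc(C)n2c(S)nncc12` and compound 3 `CC(C)c1ncn2c(S)nncc12`. In a functional assay for inhibition, with Homo sapiens as the target (on this read-out lower numbers stand for stronger inhibition and higher numbers for weaker inhibition), compound 1 gives > 48000 nM, which is a limit of the assay and not a number. Compound 2 gives > 48000 nM, again a limit. Compound 3 gives > 48000 nM, also a limit. Among the compounds with values here, the only step between measured compounds, a step that the two limits leave unreadable from compound 1 to compound 2, is hydrogen in place of methyl on a saturated chain carbon bound to an aromatic carbon. The whole of what the series shows so far is the limit of > 48000 nM in this assay, at which 3 of the 3 values shown sit.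

Compound 4, `Cc1ncn2c(S)nncc12`, is not yet measured. It differs from compound 3 by methyl in place of isopropyl on an aromatic carbon. Within the data shown here, the single measured step also shortens an alkyl substituent, and its size could not be read, so no measured step gives a readable size to carry over. Compound 4 is therefore expected to stay at the limit, with the step that the limit leaves unreadable from compound 3 to compound 4 expected to remain unreadable in this assay. The estimate for compound 4 in this assay is 100000 nM, expected to lie between 40000 nM and 300000 nM.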

Compound 4, half-maximal inhibitory concentration: > 48000 nM
Compound 4 ended at the assay's limit; the forecaster's own chance of this, stated with the estimate: 85%; the middle value is on the limit's open side.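

In this assay compound 4 joins compound 1, compound 2 and compound 3 at a limit, so no step among these four compounds can be read: the limit of > 48000 nM in this assay, at which 4 of the 4 values shown sit.

The compounds shown leave open whether any alkyl substituent on the shared core gives a readable value in this assay at all.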